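This account rests on a few compounds, and the source may have more. Where it says the series, first, only, none or still open, it means among the compounds named here.

Working notes on the series. For the measured compounds named here, compound 3 `COc1cc(-c2cc(/C=C/C(=O)c3ccc(Cl)c(Cl)c3)[nH]n2)cc(OC)c1OC` gives 97% in a functional assay on MOLT-4 cells (Homo sapiens) for cytotoxicity, read by sulforhodamine B assay, with a stated time of 48 h, tested at 1 uM (a higher number here means a weaker effect of the compound at the concentration tested, a lower number a stronger effect), the highest of the three numbers measured so far. Compound 2 `COc1ccc(-c2cc(/C=C/C(=O)c3ccc(OC)c(OC)c3)[nH]n2)cc1` gives 95%, which is within the scatter of compound 3, so no order between these two can be read. Going by the values given here, compound 1 `COc1cc(-c2cc(/C=C/C(=O)c3ccc(N)cc3)[nH]n2)cc(OC)c1OC` gives 72%, and the one step measured at the carbonyl carbon, a number 25 percentage points higher from compound 1 to compound 3 (beyond the scatter), is the only change that goes beyond the scatter.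

Compound 4 `COc1ccc(C(=O)/C=C/c2cc(-c3cc(OC)c(OC)c(OC)c3)n[nH]2)cc1` is the next member and has not yet been measured. The change from compound 3 is 4-methoxyphenyl in place of 3,4-dichlorophenyl on a carbonyl carbon. The step of a number 25 percentage points higher from compound 1 to compound 3 (beyond the scatter) concerns the same carbonyl carbon but a different pair of groups, so it bears only loosely on this change. Compound 2, which carries a methoxy-bearing aryl on its carbonyl carbon, shows a number within the scatter of compound 3, which points to little movement. The expected step is therefore a number 4 percentage points lower from compound 3 to compound 4 (within the scatter), that is, none beyond the scatter. Compound 4 is estimated at 93%, with a range from 78% to 102%.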

Compound 4, a percentage reported as activity, at one concentration (the size of the read-out at that concentration, not a potency): 102%
For compound 4 the middle estimate is 9 percentage points below the measured one, and the stated range covers the measured number.
By their numbers in this assay, from the lowest: compound 1; then compounds 2, 3 and 4 (each within the scatter of the next).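

In this assay, 4-methoxyphenyl in place of 3,4-dichlorophenyl on the carbonyl carbon gives a number 5 percentage points higher from compound 3 to compound 4 (within the scatter), so these two aryl groups cannot be told apart at this position. The amino group now has a second comparison: methoxy in its place on the aromatic carbon gives a number 30 percentage points higher from compound 1 to compound 4 (beyond the scatter), which points the same way as a number 25 percentage points higher from compound 1 to compound 3 (beyond the scatter). Of compounds 1, 3 and 4, only compound 1, with its 4-aminophenyl group, stands apart, and the exchange of one aryl group for the other at this position does not move the number beyond the scatter.

No measurement shown accounts for this result. Going by these compounds, whether a dimethylamino group, an acetamide or a hydroxyl on the same aryl ring would stay with compound 1 or with compounds 3 and 4 remains open.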